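Swapping the amide aryl group for a pyridine

The compounds below may be only part of what the source reports. "The series", "measured", "known", "first", "only" and "open" are said of these compounds alone.

Of the compounds shown here, three sharing one core have been tested in a functional assay on the whole organism for inhibition, with Rattus norvegicus as the target, read by paw edema, at a dose of 100 mg/kg by the oral route; a higher number here means more inhibition at the dose given (going by the name of the read-out), a lower number less inhibition. The simplest is compound 1 `CNC(=O)c1c(O)c2cccnc2n(-c2ccccc2)c1=O`, which gives 9.6%. Compound 2 `Cc1cccc(NC(=O)c2c(O)c3cccnc3n(-c3ccccc3)c2=O)c1` gives 14.2%, and compound 3 `COc1cccc(NC(=O)c2c(O)c3cccnc3n(-c3ccccc3)c2=O)c1` gives 5.7%. Compound 3 holds the lowest number of the three, yet its distance to either neighbour is small: a number 3.9 percentage points lower from compound 1 to compound 3 (within the scatter) and a number 8.5 percentage points lower from compound 2 to compound 3 (within the scatter), both within the scatter of this kind of measurement, as is a number 4.6 percentage points higher from compound 1 to compound 2 (within the scatter).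

The next compound, compound 4 `O=C(Nc1cccnc1)c1c(O)c2cccnc2n(-c2ccccc2)c1=O`, changes the group on the amide-type nitrogen once more: pyridin-3-yl in place of 3-methoxyphenyl on an amide-type nitrogen.

Going by the values given here, the steps that bear on this change are the two that altered the same amide-type nitrogen substituent, and neither moved the read-out beyond the scatter. The expectation for compound 4 is therefore a step of about a number 3.3 percentage points higher from compound 3 to compound 4 (within the scatter), which is no real change. Compound 4 is estimated to give 9%, within a range from 0% to 20%.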

Compound 4, a percentage reported as inhibition, in the whole organism at one dose (the size of the read-out at that dose, not a potency): 30.3%
For compound 4 the middle estimate is 21.3 percentage points below the measured one; the measured number lies above the stated range.
By their numbers in this assay, from the lowest: compounds 3, 1 and 2 (each within the scatter of the next); then compound 4.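

At this amide-type nitrogen, pyridin-3-yl in place of 3-methoxyphenyl gives a number 24.6 percentage points higher from compound 3 to compound 4 (beyond the scatter) in this assay, whereas methyl, 3-methylphenyl and 3-methoxyphenyl stayed within the scatter of one another. Compound 4 also stands apart from the other two compounds, with a number 16.1 percentage points higher from compound 2 to compound 4 (beyond the scatter) and a number 20.7 percentage points higher from compound 1 to compound 4 (beyond the scatter) on the same nitrogen, so this position can move the read-out after all, and the choice of ring here matters. Nothing shown for these compounds explains why the number rises.

Going by these compounds, with pyridin-3-yl as the only ring carrying a hetero atom, it stays open whether pyridin-2-yl or pyridin-4-yl on the same nitrogen would give a similar number. On these data alone, each compound also has a reading at one dose only, so how the inhibition changes with dose remains unknown.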